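Piperidine nitrogen substituent: cyclopropylmethyl to oxadiazolylmethyl

A few compounds are considered here, and "the series" means these few. Any claim that something is new, unique, unknown or untested is made for them only; others in the source may bear on it.

Measured so far:
compound 1 `C[C@H](CF)OC(=O)N1CCC(O[C@H]2CC[C@H](Oc3cnc(S(C)(=O)=O)cn3)CC2)CC1` gives 36.8 nM in a functional assay on isolated protein for agonist activity at Glucose-dependent insulinotropic receptor (Homo sapiens), read by HTRF and cAMP accumulation; on this read-out lower numbers stand for an effect already at smaller amounts and higher numbers for an effect only at larger amounts of compound
compound 2 `CS(=O)(=O)c1cnc(O[C@H]2CC[C@H](OC3CCN(C(=O)Oc4ccccc4)CC3)CC2)cn1` gives 9.6 nM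
compound 3 `CS(=O)(=O)c1cnc(O[C@H]2CC[C@H](OC3CCN(CC4(C(F)(F)F)CC4)CC3)CC2)cn1` gives 62.6 nM

Compound 3 carries the highest number of the three, but its gap to compound 1 is within the scatter; only compound 2 sits clearly lower. Compound 4 `CC(C)c1noc(CN2CCC(O[C@H]3CC[C@H](Oc4cnc(S(C)(=O)=O)cn4)CC3)CC2)n1` differs from compound 3 by 3-isopropyl-1,2,4-oxadiazol-5-yl in place of 1-(trifluoromethyl)cyclopropyl on a saturated chain carbon bound to an amine nitrogen in a ring. Within the data shown here, two steps bear on this position: a 6.5-fold higher number from compound 2 to compound 3 (0.81 log units; beyond the scatter) and a 1.7-fold higher number from compound 1 to compound 3 (0.23 log units; within the scatter). On these data alone, replacing the carbamates with the cyclopropylmethyl group therefore ranged from no change to a modest loss, and an aromatic heterocycle on that carbon is untested. Compound 4 is expected to move modestly back toward the lower numbers, by a 2.1-fold lower number from compound 3 to compound 4 (0.32 log units; beyond the scatter) in this assay, with wide uncertainty. Compound 4 is estimated at 30 nM, range 8 nM to 120 nM.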

Compound 4, half-maximal effective concentration: 14 nM
Compound 4: middle estimate off by 2.1-fold (0.33 log units), on the high side; measured number inside the range.
By their numbers in this assay, from the lowest: compounds 2 and 4 (each within the scatter of the next); then compounds 1 and 3 (each within the scatter of the next).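

On the amine nitrogen in a ring, a carbamate is not needed for a low number in this assay: the 3-isopropyl-1,2,4-oxadiazol-5-yl group gives a clear gain over 1-(trifluoromethyl)cyclopropyl (a 4.5-fold lower number from compound 3 to compound 4 (0.65 log units; beyond the scatter)). Against the carbamates, the (3-isopropyl-1,2,4-oxadiazol-5-yl)methyl group matches phenoxycarbonyl (a 1.5-fold higher number from compound 2 to compound 4 (0.16 log units; within the scatter)) and improves on the fluorinated carbamate (a 2.6-fold lower number from compound 1 to compound 4 (0.42 log units; beyond the scatter)). Nothing available here explains these differences.

Open, on these data alone, is whether methyl or tert-butyl in place of the isopropyl, or a pyrimidine in place of the 1,2,4-oxadiazole, would hold the number in this assay on this nitrogen.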